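This account rests on a few compounds, and the source may have more. Where it says the series, first, only, none or still open, it means among the compounds named here.

This study looks at a small set of compounds that share a two-ring core carrying a benzyl arm, and asks how strongly each one slows the growth of a human cell line. The measure throughout is a functional assay on K562 cells (Homo sapiens) for cytotoxicity, read by sulforhodamine B assay, with a stated time of 48 h; a lower number here means a stronger inhibitor of growth, a higher number a weaker inhibitor of growth.

Compound 3 `ClCc1ccc(Cn2cnc3c(Cl)nc(Cl)nc32)cc1` gives 23400 nM in this assay. Compound 1 `Nc1nc(Cl)c2ncn(Cc3ccc(CCl)cc3)c2n1` differs from it in a single place, (amino in place of chloro on an aromatic carbon), and in this assay compound 1 gives 3630 nM. Among the measured compounds shown here, the resulting step, a 6.4-fold lower number from compound 3 to compound 1 (0.81 log units; beyond the scatter), is the only measured instance of this change.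

Compound 2 `ClCc1cccc(Cn2cnc3c(Cl)nc(Cl)nc32)c1` contains the same atoms as compound 3 joined differently; the difference between the two cores is not broken down here. In this assay compound 2 gives 1580 nM, the lowest number among the three measured compounds, with compound 1 nearest to it and compound 3 furthest away.

Compound 4 `Nc1nc(Cl)c2ncn(Cc3cccc(CCl)c3)c2n1` has not yet been measured. It stands to compound 2 exactly as compound 1 stands to compound 3: amino in place of chloro on an aromatic carbon. The surroundings of the change are the same in both pairs, so this is the same change rather than merely a similar one. For the measured compounds named here, a step in the same downward direction is therefore expected, estimated as a 5.3-fold lower number from compound 2 to compound 4 (0.72 log units; beyond the scatter), because a 6.4-fold lower number from compound 3 to compound 1 (0.81 log units; beyond the scatter) was seen for the one pair already measured, with the size tempered slightly since it rests on a single example. Compound 4 is accordingly estimated at 300 nM in this assay, most likely falling between 100 nM and 1000 nM.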

Compound 4, concentration for 50% growth inhibition: 4360 nM
The estimate for compound 4 lay 15-fold (1.16 log units) below the measured number; the measured number lies above the stated range.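

In this assay, placing amino instead of chloro on the aromatic carbon between two ring nitrogen atoms gives a 2.8-fold higher number from compound 2 to compound 4 (0.44 log units; beyond the scatter), so the drop seen on the other core does not recur here. Set side by side, the same change moves the number in opposite directions on the two cores, and the gap between the steps is larger than repeated measurements would explain: the same change on two cores in this assay, a 6.4-fold lower number (0.81 log units; beyond the scatter) from compound 3 to compound 1 and a 2.8-fold higher number (0.44 log units; beyond the scatter) from compound 2 to compound 4, 18-fold (1.25 log units) apart, beyond the scatter of two such steps. Among the compounds shown here, this shows that, in this series, the result of the change on one core cannot simply be carried over to the other, even though the local surroundings of the swapped atom match; it does not show why the two pairs part ways, nor which of them would be the more typical, since only two pairs exist.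

The compounds shown leave open whether the reversal is tied to amino itself or would also appear with another group on that carbon, such as methoxy or methylamino. They also leave open how the change would behave on further cores, for instance one with a plain methyl group in place of the chlorine-bearing carbon of the benzyl arm.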